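Extending the hydroxyalkyl amide tail of a spirocyclic cholesterol-transporter binder

The source may report more compounds than this note shows. Statements on the series, on what has been measured and on what is new or still open speak of the compounds shown alone.

The measured compounds:
compound 1, `O=C(CN1CN(c2ccccc2)C2(CCN(C(=O)c3ccc(C4CCCCC4)cc3)CC2)C1=O)NCCCCO`, 10300 nM
compound 2, `CC(C)(C)c1ccc(C(=O)N2CCC3(CC2)C(=O)N(CC(=O)NCCCCO)CN3c2ccccc2)cc1`, 19200 nM
compound 3, `CC(C)(C)c1ccc(C(=O)N2CCC3(CC2)C(=O)N(CC(=O)NCNS(C)(=O)=O)CN3c2ccccc2)cc1`, 3200 nM

In an assay on HEK293 cells for displacement of a labelled ligand from NPC1-like intracellular cholesterol transporter 1 (Homo sapiens) (a lower number here means a stronger inhibitor, a higher number a weaker inhibitor), compound 1 stands second highest of the three numbers shown. Its nearest neighbour is compound 2, the step being a 1.9-fold higher number from compound 1 to compound 2 (0.27 log units; within the scatter), which is a swap of tert-butyl in place of cyclohexyl on an aromatic carbon. Among the measured compounds shown here, compound 3 lies furthest from it, and the step of a 6.0-fold lower number from compound 2 to compound 3 (0.78 log units; beyond the scatter) is the one change in the set that touches the amide-bearing chain.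

Compound 4, `CC(C)(C)OC(=O)NCCCNC(=O)CN1CN(c2ccccc2)C2(CCN(C(=O)c3ccc(C4CCCCC4)cc3)CC2)C1=O`, keeps the cyclohexyl side of compound 1 and alters only the chain end: (tert-butoxycarbonyl)amino in place of hydroxymethyl on a saturated chain carbon, three bonds along the chain from an amide-type nitrogen. For the measured compounds named here, no measured step shows exactly this exchange. Going by the values given here, the only related information is the step from compound 2 to compound 3, where replacing the hydroxyl-terminated chain by a nitrogen-bearing group gave a modest lowering of the number beyond the scatter. A carbamate-type terminus is not a sulfonamide, so the carry-over is uncertain, and a step of at most modest size, toward a lower number, is expected in this assay. Compound 4 is therefore estimated at 6000 nM, within 2000 nM to 18000 nM, corresponding to an expected step of a 1.7-fold lower number from compound 1 to compound 4 (0.23 log units; within the scatter).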

Compound 4, half-maximal inhibitory concentration: 6000 nM
Beside the measured number, compound 4's estimate shows no gap at the digits printed, within the range that was stated.
By their numbers in this assay, from the lowest: compounds 3, 4, 1 and 2 (each within the scatter of the next, the first and the last beyond it).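

In this assay, the chain end of compound 1 takes a much larger terminus without a step beyond the scatter: a 1.7-fold lower number from compound 1 to compound 4 (0.23 log units; within the scatter), as 8 heavy atoms enter where 2 leave, on a saturated chain carbon, three bonds along the chain from an amide-type nitrogen. This is the first change at the chain end shown on the cyclohexyl side, since the earlier change there, in the step to compound 3, was made on the tert-butyl side, and it shows that the added bulk of the carbamate terminus does not carry the number out of the scatter around compound 1. Nothing presented here accounts for this outcome, and no supporting measurement bears on it.

The compounds shown leave open whether a free amine, the group that would remain with the tert-butoxycarbonyl removed, or a carboxylic acid at the same chain end would also stay within the scatter of compound 1. They also leave open whether a methanesulfonamido terminus on the cyclohexyl side would repeat a 6.0-fold lower number from compound 2 to compound 3 (0.78 log units; beyond the scatter), or whether a longer chain would change the reading.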